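The compounds below may be only part of what the source reports. "The series", "measured", "known", "first", "only" and "open" are said of these compounds alone.

Measured so far:
- compound 1, `COc1cc(/C(F)=C/c2cc(O)c3ccoc3c2)cc(OC)c1OC`: > 1000 nM
- compound 2, `COc1ccc(/C(F)=C/c2cc(OC)c(OC)c(OC)c2)cc1F`: 610000 nM
- compound 3, `COc1ccc(/C(F)=C(\F)c2cc(OC)c(OC)c(OC)c2)cc1N`: 204000 nM

In a functional assay on cells (Endothelial cell, Bos taurus) for antiproliferative activity (on this read-out lower numbers stand for stronger inhibition and higher numbers for weaker inhibition), compound 1 gives > 1000 nM, which is a limit of the assay and not a number. Compound 2 gives 610000 nM in this assay, the highest of the two numbers available. Compound 3 gives 204000 nM in this assay, a lower number than that of compound 2, and the gap between them lies beyond the usual scatter. Compound 1 sits at the limit of > 1000 nM in this assay, at which 1 of the 3 values shown sits, so it offers no number for comparison.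

Compound 4, `COc1ccc(/C(F)=C/c2cc(OC)c(OC)c(OC)c2)cc1O`, is not yet measured. It differs from compound 2 by hydroxy in place of fluoro on an aromatic carbon. Among the measured compounds shown here, no measured pair shows this same change, so the size of the step is open; the only clue is that compound 3, carrying a different substituent at this aromatic carbon, gives 204000 nM. A lower number for compound 4 than for compound 2 is expected, by a step of a 10-fold lower number from compound 2 to compound 4 (1.01 log units; beyond the scatter). For compound 4 the estimate in this assay is 60000 nM, with a range from 5000 nM to 400000 nM.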

Compound 4, half-maximal inhibitory concentration: 26600 nM
Estimate against measurement, compound 4: 2.3-fold (0.35 log units) above; the range from low to high includes it.
By their numbers in this assay, from the lowest: compound 4; then compound 3; then compound 2.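

In this assay, hydroxy in place of fluoro on an aromatic carbon, ortho to a methoxy group and meta to a large group, gives a 23-fold lower number from compound 2 to compound 4 (1.36 log units; beyond the scatter), so the number at this position depends on the group it carries. Among the compounds shown here, compound 3 differs from compound 2 in more than one place and could not show this; the pair of compound 2 and compound 4 is the first to isolate the position. Nothing measured in the series accounts for the size of this step.

Whether the change depends on hydroxy itself stays open, since no other group, such as chloro or a carboxylic acid, is shown at this carbon on the same core. From the compounds shown here alone, whether the same exchange at other aromatic carbons gives a comparable step also stays open.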